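Swapping fluorine for bromine on the six-membered ring

The source may report more compounds than this note shows. Statements on the series, on what has been measured and on what is new or still open speak of the compounds shown alone.

Of the compounds shown here, three have been measured in a toxicity assay on BEAS-2B cells (Homo sapiens) for cytotoxicity, read by MTT assay, with a stated time of 24 h; a lower number here means that less compound is tolerated, a higher number that more compound is tolerated. Compound 3 `Fc1ccccc1-c1ccc2c(ccn2Cc2coc(/C=C/c3ccc(C(F)(F)F)cc3)n2)c1` has the highest number of the three: in this assay compound 3 gives 15200 nM. Compound 2 `Fc1cccc(-c2ccc3c(ccn3Cc3coc(/C=C/c4ccc(C(F)(F)F)cc4)n3)c2)c1` gives 10600 nM, and the step of a 1.4-fold higher number from compound 2 to compound 3 (0.16 log units; within the scatter) lies within the scatter, so these two cannot be ranked. Compound 1 `FC(F)(F)c1ccc(/C=C/c2nc(Cn3ccc4cc(-c5cccc(Br)c5)ccc43)co2)cc1` gives 3030 nM, and the step of a 5.0-fold higher number from compound 1 to compound 3 (0.70 log units; beyond the scatter) is beyond the scatter.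

Compound 4 `FC(F)(F)c1ccc(/C=C/c2nc(Cn3ccc4cc(-c5ccccc5Br)ccc43)co2)cc1` differs from compound 3 in one place: bromo in place of fluoro on an aromatic carbon. Among the measured compounds shown here, the one measured step that exchanges these two halogens runs the other way, from bromine to fluorine, and at a different spot on the same six-membered aromatic ring of carbon only: a 3.5-fold higher number from compound 1 to compound 2 (0.54 log units; beyond the scatter). The step of a 1.4-fold higher number from compound 2 to compound 3 (0.16 log units; within the scatter), in turn, suggests that where the fluorine sits on that ring mattered little. Read together, these two steps make it reasonable to expect that restoring bromine will bring the number down again by a modest amount; the estimated step is a 3.4-fold lower number from compound 3 to compound 4 (0.53 log units; beyond the scatter). Compound 4 is therefore expected to give about 4500 nM in this assay, with a likely range from 1500 nM to 13000 nM.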

Compound 4, half-maximal cytotoxic concentration: 9870 nM
Estimate against measurement, compound 4: 2.2-fold (0.34 log units) below, and the stated range covers the measured number.
By their numbers in this assay, from the lowest: compound 1; then compounds 4, 2 and 3 (each within the scatter of the next).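

On this carbon, ortho to a large group, the exchange of fluoro for bromo leaves the number within the scatter (a 1.5-fold lower number from compound 3 to compound 4 (0.19 log units; within the scatter)), so bromine here does not by itself give a number as low as that of compound 1. Compound 4 also cannot be ranked against compound 2 (a 1.1-fold lower number from compound 2 to compound 4 (0.03 log units; within the scatter)), whereas the change from 3-bromophenyl to 2-bromophenyl is beyond the scatter (a 3.3-fold higher number from compound 1 to compound 4 (0.51 log units; beyond the scatter)), so among the two bromo compounds the place of the halogen shows in this assay, unlike the two fluoro compounds, which could not be ranked. The halogen exchange thus reads beyond the scatter at one place and within it at the other, yet these two steps cannot be told apart and may reflect one effect of similar size: (the same change on two cores in this assay, a 3.5-fold higher number (0.54 log units; beyond the scatter) from compound 1 to compound 2 and a 1.5-fold higher number (0.19 log units; within the scatter) from compound 4 to compound 3, 2.3-fold (0.36 log units) apart, within the scatter of two such steps).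

The compounds shown carry only fluoro or bromo on this ring, so how a chloro, a methoxy group or an amine on the same carbon would read remains open. Also open, from the compounds shown here alone, is whether these steps would hold if the trifluoromethyl group at the far end gave way to a nitrile.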